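This account rests on a few compounds, and the source may have more. Where it says the series, first, only, none or still open, it means among the compounds named here.

Compound 3, `Cc1ccc(-c2nccs2)c(C(=O)N2CC3(CC3)C[C@H]2CNc2ccc(C(F)(F)F)cn2)n1`, is the higher of the two numbers recorded in a functional assay on HEK293 cells for antagonist activity at Orexin receptor type 2 (Homo sapiens), read by FLIPR and calcium flux (on this read-out lower numbers stand for lower potency and higher numbers for higher potency (the scale is a negative logarithm)), where compound 3 gives 8. Its nearest neighbour is compound 1, `Cc1ccnc(NC[C@@H]2CC3(CC3)CN2C(=O)c2nc(C)sc2-c2ccccc2)n1`, which in this assay gives 7, a gap that lies beyond the scatter. Compound 2, `Cc1ccc(-n2nccn2)c(C(=O)N2CC3(CC3)C[C@H]2CNc2ccc(Cl)cn2)c1`, yields only a limit in this assay, < 5, and not a number. The next compound, compound 4, `Cc1ccc(OCc2ccccc2)c(C(=O)N2CC3(CC3)C[C@H]2CNc2ccc(C(F)(F)F)cn2)n1`, has not yet been measured. It differs from compound 3 in one place: benzyloxy in place of 1,3-thiazol-2-yl on an aromatic carbon. Going by the values given here, no measured pair shows this change, so its size is open; a modest loss, somewhat beyond the scatter, is expected. Compound 4 is estimated at 7.3, with a likely range from 6.5 to 8.1. The expected step is a number 0.70 log units lower from compound 3 to compound 4 (beyond the scatter).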

Compound 4, negative logarithm of the antagonist equilibrium constant: 8.6
The estimate for compound 4 lay 1.30 log units below the measured number, outside the stated range (above it).
By their numbers in this assay, from the lowest: compound 1; then compound 3; then compound 4. At a limit, below all of these: compound 2.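

Exchanging 1,3-thiazol-2-yl for benzyloxy on this aromatic carbon, ortho to a large group, gives in this assay a number 0.60 log units higher from compound 3 to compound 4 (beyond the scatter). For this pair, then, the five-membered aromatic ring with 2 hetero atoms is not needed at this position, and benzyloxy, with its six-membered aromatic ring of carbon only, is more than tolerated. Nothing measured here accounts for the gain. Going by these compounds, it remains open whether the ring in benzyloxy matters or the oxygen link does, and how a methoxy or a benzylamino group would read at this position.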